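The source may hold more compounds than are shown below. What is called first, only, known or untested is meant among the compounds shown, and "the series" means these compounds.

Working notes on the pyrazole series

Compound 1 `Oc1ccc(O)c(-c2cc(-c3ccccc3)nn2-c2ccccc2)c1` is the parent. In a functional assay on cells (Cancer cell lines, Homo sapiens) for cytotoxicity, read by sulforhodamine B assay, with a stated time of 48 h (a higher number here means a weaker inhibitor of growth, a lower number a stronger inhibitor of growth), compound 1 gives 22600 nM. Compound 2 `Oc1ccc(O)c(-c2cc(-c3ccc(Cl)cc3)nn2-c2ccccc2)c1` differs from compound 1 by chloro in place of hydrogen on an aromatic carbon; in this assay compound 2 gives 8860 nM, which is a 2.6-fold lower number from compound 1 to compound 2 (0.41 log units; beyond the scatter).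

Compound 3 `CC(=O)NS(=O)(=O)c1ccc(-n2nc(-c3ccccc3)cc2-c2cc(O)ccc2O)cc1` carries a different core, which differs from that of compound 1 by acetylsulfamoyl in place of hydrogen on an aromatic carbon. In this assay, among the measured compounds shown here, compound 3 gives 78100 nM, which is a 3.5-fold higher number from compound 1 to compound 3 (0.54 log units; beyond the scatter), and is the highest of the three numbers so far.

Compound 4 `CC(=O)NS(=O)(=O)c1ccc(-n2nc(-c3ccc(Cl)cc3)cc2-c2cc(O)ccc2O)cc1` has not yet been measured. It differs from compound 3 by chloro in place of hydrogen on an aromatic carbon. This is the same change as that from compound 1 to compound 2: both put chloro in place of hydrogen on an aromatic carbon, para to a large group, and the two place descriptions agree word for word. What separates the two pairs is only the core, as described above between compound 1 and compound 3.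

Expectation for compound 4: the step is expected to be about a 2.6-fold lower number from compound 3 to compound 4 (0.42 log units; beyond the scatter), resting on the single earlier instance where the same change gave a 2.6-fold lower number from compound 1 to compound 2 (0.41 log units; beyond the scatter). For the measured compounds named here, whether the change behaves alike on the acetylsulfamoyl-bearing core is unknown; only one example of the change exists, so the range is kept wide. On this basis compound 4 in this assay is estimated at 30000 nM, with a likely range from 12000 nM to 75000 nM.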

Compound 4, concentration for 50% growth inhibition: 23500 nM
For compound 4 the middle estimate is 1.3-fold (0.11 log units) above the measured one, within the range that was stated.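

In this assay, chloro in place of hydrogen on the acetylsulfamoyl-bearing core gives a 3.3-fold lower number from compound 3 to compound 4 (0.52 log units; beyond the scatter), so the change carries over from the core of compound 1 to this core with much the same size: the same change on two cores in this assay, a 2.6-fold lower number (0.41 log units; beyond the scatter) from compound 1 to compound 2 and a 3.3-fold lower number (0.52 log units; beyond the scatter) from compound 3 to compound 4, 1.3-fold (0.11 log units) apart, within the scatter of two such steps

Read the other way, acetylsulfamoyl in place of hydrogen gives a 2.7-fold higher number from compound 2 to compound 4 (0.42 log units; beyond the scatter), and this change also keeps its direction and size whether the other aryl group is phenyl or 4-chlorophenyl: the same change on two cores in this assay, a 3.5-fold higher number (0.54 log units; beyond the scatter) from compound 1 to compound 3 and a 2.7-fold higher number (0.42 log units; beyond the scatter) from compound 2 to compound 4, 1.3-fold (0.11 log units) apart, within the scatter of two such steps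

Within these four compounds the two changes therefore act independently of each other as far as can be read, but this rests on a single square of compounds in one assay, with chloro at one place only, and it shows neither why the numbers move nor that another pair of changes would combine in the same way.

Going by these compounds, it remains open whether a group other than chloro at this place, such as methoxy, an amine or a carboxylic acid, would carry across the two cores as chloro does. On these data alone, it also remains open whether the same holds when the acetylsulfamoyl group is replaced by a plain sulfonamide or a carboxylic acid, or when chloro sits on the other phenyl ring.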